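Swapping Bromo for Nitro on a Compound with the Lowest Number

The compounds below may be only part of what the source reports. "The series", "measured", "known", "first", "only" and "open" are said of these compounds alone.

Three compounds sharing one core were tested in an assay on membranes from brain for binding affinity to adenosine receptor A1 (Rattus norvegicus), read by radioligand binding, tested at 20 uM; on this read-out lower numbers stand for less inhibition and higher numbers for more inhibition at the one concentration tested (going by the name of the read-out). Compound 1, `Cn1c(=O)[nH]c2c(cnn2-c2ccccc2Br)c1=N`, gives 6%. Compound 2, `Cn1c(=O)[nH]c2c(cnn2-c2cc(Cl)cc(Cl)c2)c1=N`, gives 29%, and compound 3, `Cn1c(=O)[nH]c2c(cnn2-c2ccc(Cl)cc2)c1=N`, gives 37%. Among these three numbers compound 1 stands lowest: the nearest value, that of compound 2, lies above it by more than the usual scatter, and the furthest, that of compound 3, lies still further above. Within the data shown here, no two of the measured compounds differ in a single place, so no measured step can guide the next change directly.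

Compound 4, `Cn1c(=O)[nH]c2c(cnn2-c2ccccc2[N+](=O)[O-])c1=N`, is built from compound 1 by one change: nitro in place of bromo on an aromatic carbon. Among the measured compounds shown here, with no measured step of this kind at hand, the step in this assay is expected to be small, and not clearly beyond the scatter. The expected step of a number 6 percentage points higher from compound 1 to compound 4 (within the scatter) is accordingly modest, tending upward if anything. In this assay compound 4 is thus expected to give about 12%, with a range from 0% to 35%.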

Compound 4, a percentage reported as inhibition, at one concentration (the size of the read-out at that concentration, not a potency): 5%
Estimate against measurement, compound 4: 7 percentage points above; low and high end bracket the measured number.
By their numbers in this assay, from the lowest: compounds 4 and 1 (each within the scatter of the next); then compounds 2 and 3 (each within the scatter of the next).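

In this assay, among these compounds, nitro in place of bromo on an aromatic carbon, ortho to a large group, gives a number 1 percentage points lower from compound 1 to compound 4 (within the scatter) and is the first measured single-place step. At this position, then, a group of 3 heavy atoms with 2 hydrogen-bond acceptors can replace a single bromine atom with no shift in the read-out beyond the scatter. Nothing measured here explains why these two groups give matching numbers.

Still open, on these data alone, is whether a group of another kind at this position, such as an amine or a carboxylic acid, would move the number beyond the scatter. Equally open, as far as these compounds go, is whether nitro in place of bromo would give a similarly small step on another carbon of the same ring.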